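Swapping the side group on the ring nitrogen of compound 2

This account rests on a few compounds, and the source may have more. Where it says the series, first, only, none or still open, it means among the compounds named here.

Compound 2 `O=C(Cc1nn(CC(=O)N2CCOCC2)c(=O)c2ccccc12)Nc1ccc(OC(F)(F)F)c(Cl)c1` is one of three related compounds tested in a functional assay on CHO cells for antagonist activity at sphingosine 1-phosphate receptor 2 (Homo sapiens), read by GTPgammaS binding; on this read-out lower numbers stand for stronger inhibition and higher numbers for weaker inhibition. Compound 2 gives 103 nM, the lowest of the three numbers. Compound 3 `C[C@@H](C(=O)O)c1nn(Cc2cn3cc(OCC4CC4)c(Cl)cc3n2)c2ccccc2c1=O` gives 253 nM in this assay, and compound 1 `CCn1nc(CC(=O)Nc2ccc(OC(F)(F)F)c(Cl)c2)c2ccccc2c1=O` gives 473 nM. Compound 1 and compound 2 share a core and differ only on one saturated chain carbon bound to an aromatic nitrogen, and that single change brought a 4.6-fold lower number from compound 1 to compound 2 (0.66 log units; beyond the scatter). The new compound 4 `O=C(Cc1nn(C2CCNC2)c(=O)c2ccccc12)Nc1ccc(OC(F)(F)F)c(Cl)c1` again changes the group on that aromatic nitrogen: pyrrolidin-3-yl in place of ((morpholin-4-yl)carbonyl)methyl on an aromatic nitrogen. Among the measured compounds shown here, the only step that bears on this is the one from compound 1 to compound 2, where a larger group on the same chain lowered the number modestly; the pyrrolidin-3-yl group that enters is smaller than what leaves but larger than the methyl of compound 1, so a move back toward a higher number, of modest size, is expected, a 2.4-fold higher number from compound 2 to compound 4 (0.39 log units; beyond the scatter). Compound 4 is estimated at 250 nM, with a range from 60 nM to 1000 nM.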

Compound 4, half-maximal inhibitory concentration: 42 nM
For compound 4 the middle estimate is 6.0-fold (0.77 log units) above the measured one; the whole stated range lies above it.
By their numbers in this assay, from the lowest: compound 4; then compound 2; then compounds 3 and 1 (each within the scatter of the next).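

The lower number at this ring nitrogen does not depend on the morpholine amide: with pyrrolidin-3-yl in its place, this assay shows a 2.5-fold lower number from compound 2 to compound 4 (0.39 log units; beyond the scatter), even though the entering group is smaller and has no carbonyl. Measured against the ethyl group, the same ring gives an 11-fold lower number from compound 1 to compound 4 (1.05 log units; beyond the scatter), so this position responds strongly to what it carries. Across these three compounds the number does not follow group size, as the mid-sized pyrrolidin-3-yl gives a lower number than both the larger ((morpholin-4-yl)carbonyl)methyl and the smaller ethyl. Nothing available explains these steps.

From the compounds shown here alone, it remains open whether the ring itself or its nitrogen with its hydrogen matters more. A piperidin-4-yl group, an open 2-aminoethyl chain or a pyrrolidine with a methyl on its nitrogen would help separate the two.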